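A few compounds are considered here, and "the series" means these few. Any claim that something is new, unique, unknown or untested is made for them only; others in the source may bear on it.

Measured in an assay on isolated protein for inhibition of pancreatic alpha-amylase (Sus scrofa); on this read-out higher numbers stand for weaker inhibition and lower numbers for stronger inhibition: compound 1 `CCOc1ccc2nc(N/C(=C\C(=O)c3ccc(C)cc3)SC)sc2c1` gives 18900 nM; compound 2 `CCOc1ccc2nc(N/C(=C\C(=O)c3ccccc3)SC)sc2c1` gives 16300 nM.

On the numbers shown, compound 2 stands next to compound 1, the two within the scatter of each other. Compound 3 `CCOc1ccc2nc(N/C(=C\C(=O)c3ccc(OC)cc3)SC)sc2c1` differs from compound 2 by methoxy in place of hydrogen on an aromatic carbon. Going by the values given here, the only measured step that bears on this, a 1.2-fold lower number from compound 1 to compound 2 (0.06 log units; within the scatter), concerns hydrogen in place of methyl on an aromatic carbon and stayed within the scatter. For compound 3 a step of a 1.1-fold lower number from compound 2 to compound 3 (0.04 log units; within the scatter) is therefore expected, none beyond the scatter. Compound 3 is estimated at 15000 nM, within 7000 nM to 35000 nM.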

Compound 3, half-maximal inhibitory concentration: 18600 nM
The estimate for compound 3 lay 1.2-fold (0.09 log units) below the measured number, within the range that was stated.
By their numbers in this assay, from the lowest: compounds 2, 3 and 1 (each within the scatter of the next).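

In (this assay), methoxy in place of hydrogen on the aromatic carbon para to a large group gives (a 1.1-fold higher number from compound 2 to compound 3 (0.06 log units; within the scatter)), and methoxy in place of methyl gives (a 1.0-fold lower number from compound 1 to compound 3 (0.01 log units; within the scatter)). Hydrogen, methyl and methoxy at this position therefore all read alike, so a group attached through oxygen reads the same as one attached through carbon. No evidence on the reason for this accompanies the result.

Still open, from the compounds shown here alone, is whether an amine, a carboxylic acid or a longer chain at this position would move the number beyond the scatter. Equally open, going by these compounds, is whether any change elsewhere on the shared core would do so.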